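A trifluoromethyl group added to compound 3

The source may report more compounds than this note shows. Statements on the series, on what has been measured and on what is new or still open speak of the compounds shown alone.

Measured values in a physicochemical assay for solubility, measured as kinetic solubility (a higher number here means a more soluble compound, a lower number a less soluble compound), for the three compounds:
compound 1 `Cc1n[nH]c(-c2ncc3c(N(C)C)ccnc3c2O)n1` gives > 250000 nM (a limit)
compound 2 `Cc1n[nH]c(-c2ncc3c(N4CCCCS4(=O)=O)ccnc3c2O)n1` gives 250000 nM
compound 3 `Cc1n[nH]c(-c2ncc3c(-c4ccccc4)ccnc3c2O)n1` gives 160000 nM

Compound 1 reads > 250000 nM as a limit of the assay and not as a number. Compound 3, at 160000 nM in this assay, lies within the scatter of compound 2, so neither can be ranked above the other. Compound 4 `Cc1n[nH]c(-c2ncc3c(-c4ccccc4C(F)(F)F)ccnc3c2O)n1` differs from compound 3 by trifluoromethyl in place of hydrogen on an aromatic carbon in its structure. Among the measured compounds shown here, no measured step adds a group to the phenyl, so the evidence is indirect. Going by these compounds, exchanging the group on the core gave a 1.6-fold lower number from compound 2 to compound 3 (0.19 log units; within the scatter) and an at least 1.5-fold lower number from compound 1 to compound 3 (0.19 log units; that floor lies within the scatter) as its two readable changes, while a number no higher from compound 1 to compound 2 (the limit leaves the size open) stays open in size. On those small steps, only a modest fall is expected, possibly within the scatter. The expected change is a 1.3-fold lower number from compound 3 to compound 4 (0.12 log units; within the scatter) in this estimate. Compound 4 is expected near 120000 nM, with an estimated range of 50000 nM to 240000 nM for its reading.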

Compound 4, solubility: > 250000 nM
Compound 4: only a limit was reported; the forecaster's own chance of this, stated with the estimate: 10%; middle value at least 2.0-fold (0.31 log units) away from the limit.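

In this assay, compound 4 reads > 250000 nM, which is a limit of the assay and not a number. Earlier changes were all made to the group on the shared core, whereas this one lies on an aromatic carbon of the six-membered aromatic ring of carbon only, ortho to a large group, and trifluoromethyl in place of hydrogen there gave an at least 1.5-fold higher number from compound 3 to compound 4 (0.19 log units; that floor lies within the scatter), so no loss shows at this position. The top of the readable range now restricts what this series can show: the limit of > 250000 nM in this assay, at which 2 of the 4 values shown sit.

Going by these compounds, how far compound 4 lies past its limit stays open, so the true size of this step is unknown. Also open, on these data alone, is whether a methyl group or an amine at the same place would read the same.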